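Cytotoxicity notes on the aryl sulfonamide series: compound 4 expected

The source may hold more compounds than are shown below. What is called first, only, known or untested is meant among the compounds shown, and "the series" means these compounds.

Three compounds of the series have been run in an ADME assay on HEK293 cells (Homo sapiens) for cytotoxicity, read by resazurin assay, with a stated time of 48 h; on this read-out lower numbers stand for higher toxicity in this test and higher numbers for lower toxicity in this test. Compound 1 `O=S(=O)(Nc1ccc2oc(-c3ccccc3)nc2c1)c1cccc(C(F)(F)F)c1` gives > 100000 nM, which is a limit of the assay rather than a number. Compound 2 `CS(=O)(=O)Nc1ccc(-c2nc3ccccc3o2)cc1` likewise gives > 100000 nM, again only a limit. Within the data shown here, compound 3 `CCc1ccc(S(=O)(=O)Nc2ccc3oc(-c4ccccc4)nc3c2)cc1` is the one compound with a number, giving 81000 nM in this assay. Compound 2 thus stands where no number is known for it: its value is a limit, and one of the other two values shown is a limit as well, as captured by the limit of > 100000 nM in this assay, at which 2 of the 3 values shown sit. Compound 3 sits close to that limit.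

The next compound, compound 4 `COc1cccc(S(=O)(=O)Nc2ccc(-c3nc4ccccc4o3)cc2)c1`, is not yet measured in this assay. It differs from compound 2 by 3-methoxyphenyl in place of methyl on a sulfonyl sulfur. Among the measured compounds shown here, no step between measured compounds with a single change is available. The expectation rests on the values shown: compound 2 gives only a limit. Compound 3 gives 81000 nM, a number. Compound 4 is therefore expected at 100000 nM, within 50000 nM to 200000 nM, in this assay, and a limit is about as likely as a number. The expected step is a number no higher from compound 2 to compound 4 (the limit leaves the size open), none beyond the scatter.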

Compound 4, half-maximal cytotoxic concentration: > 100000 nM
Compound 4: a limit, no number; the forecaster's own chance of this, stated with the estimate: 50%; the middle value lies on the limit itself.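

In this assay compound 4 gives > 100000 nM, a limit of the assay and not a number. Compound 2 is also a limit, so no step can be read between compound 2 and compound 4. Left open is whether 3-methoxyphenyl in place of methyl on a sulfonyl sulfur changes the read-out at all, with most values resting on one limit: the limit of > 100000 nM in this assay, at which 3 of the 4 values shown sit.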